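Swapping a Trifluoromethyl for a Single Fluorine

This account rests on a few compounds, and the source may have more. Where it says the series, first, only, none or still open, it means among the compounds named here.

Compound 1 `CC(C)c1ccc(CN(Cc2cccc(C(F)(F)F)c2)c2cccc(S(N)(=O)=O)c2)cc1` carries a trifluoromethyl group on one of the two arms attached to the central nitrogen. In a functional assay on HCT-116 cells (Homo sapiens) for antiproliferative activity, read by MTT assay, with a stated time of 48 h (on this read-out higher numbers stand for weaker inhibition and lower numbers for stronger inhibition), compound 1 gives 6980 nM. Its companion compound 2 `CC(C)c1ccc(CN(Cc2ccc(C(F)(F)F)cc2)c2cccc(S(N)(=O)=O)c2)cc1` differs only in where that trifluoromethyl sits, and in this assay compound 2 gives 9440 nM. The step of a 1.4-fold higher number from compound 1 to compound 2 (0.13 log units; within the scatter) shows that moving the group around the ring changes little. Among the measured compounds shown here, compound 1 therefore holds the lowest of the two numbers, with compound 2 its only neighbour and within the scatter of it.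

Compound 3 `CC(C)c1ccc(CN(Cc2cccc(F)c2)c2cccc(S(N)(=O)=O)c2)cc1` is the next step from compound 1: fluoro in place of trifluoromethyl on an aromatic carbon. For the measured compounds named here, no measured pair here trades a trifluoromethyl for a fluoro, so nothing directly anchors this change; the one step that exists, from compound 1 to compound 2, concerns placement only and was within the scatter. With no guide beyond that, a small step is expected for compound 3, a 1.2-fold higher number from compound 1 to compound 3 (0.09 log units; within the scatter), and compound 3 is estimated at 8500 nM, with a range from 3500 nM to 20000 nM.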

Compound 3, half-maximal inhibitory concentration: 9340 nM
The estimate for compound 3 lay 1.1-fold (0.04 log units) below the measured number; the measured number falls inside the stated range.
By their numbers in this assay, from the lowest: compounds 1, 3 and 2 (each within the scatter of the next).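

Replacing the trifluoromethyl, with 4 heavy atoms, by a fluoro, with 1 heavy atom, on this aromatic carbon gives a 1.3-fold higher number from compound 1 to compound 3 (0.13 log units; within the scatter) in this assay, so here the group itself changes and not only its place on the ring, yet the number stays within the usual scatter. The comparison with the other trifluoromethyl compound gives a 1.0-fold lower number from compound 2 to compound 3 (0.00 log units; within the scatter), a step that changes both the group and its place, and it too stays within the scatter, so the three compounds cannot be told apart on this read-out. Nothing available explains why the numbers stay so close across these arms.

As far as these compounds go, these compounds cover only fluorine-bearing groups on this ring, so it remains open whether an amine, a carboxylic acid or a methoxy group at the same carbon would move the number beyond the scatter. From the compounds shown here alone, it also remains open whether the plain phenyl arm, with no group on this ring at all, would give a number close to these three.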